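Cytotoxicity on a Shared Core: From Trifluoromethoxy to Phenyl

This account rests on a few compounds, and the source may have more. Where it says the series, first, only, none or still open, it means among the compounds named here.

Compound 1 `Cc1c(Cc2ccc(Br)cc2)c(=O)oc2cc(OCC(O)CN3CCC(C(N)=O)CC3)ccc12`: > 100000 nM
Compound 2 `Cc1cc(F)ccc1Cc1c(C)c2ccc(OCC(O)CN3CCC(C(N)=O)CC3)cc2oc1=O`: > 100000 nM
Compound 3 `Cc1c(Cc2ccc(OC(F)(F)F)cc2)c(=O)oc2cc(OCC(O)CN3CCC(C(N)=O)CC3)ccc12`: 68200 nM

In an ADME assay on A549 cells (Homo sapiens) for cytotoxicity, read by CellTiter-Glo (on this read-out lower numbers stand for higher toxicity in this test and higher numbers for lower toxicity in this test), compound 1 reaches only a limit, > 100000 nM. Compound 2 likewise stops at a limit, > 100000 nM. For the measured compounds named here, compound 3 is the single compound with a number, giving 68200 nM in this assay, so it stands as the only measured point among three values. The steps into it are floors only: an at least 1.4-fold lower number from compound 1 to compound 3 (0.16 log units; that floor lies within the scatter) and an at least 1.4-fold lower number from compound 2 to compound 3 (0.16 log units; that floor lies within the scatter), both resting on (the limit of > 100000 nM in this assay, at which 2 of the 3 values shown sit), while a step that the two limits leave unreadable from compound 1 to compound 2 cannot be read at all.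

Compound 4 `Cc1c(Cc2ccc(-c3ccccc3)cc2)c(=O)oc2cc(OCC(O)CN3CCC(C(N)=O)CC3)ccc12` differs from compound 3 by phenyl in place of trifluoromethoxy on an aromatic carbon. Going by the values given here, none of the measured steps shows a phenyl entering, and the two steps that reach compound 3 are floors within the scatter, so no step beyond the scatter is expected in this assay, namely a 1.1-fold lower number from compound 3 to compound 4 (0.06 log units; within the scatter). Compound 4 is therefore estimated at 60000 nM, within a range from 25000 nM to 150000 nM.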

Compound 4, half-maximal cytotoxic concentration: > 100000 nM
Compound 4 was reported as a limit; the forecaster's own chance of this, stated with the estimate: 35%; middle value at least 1.6-fold (0.22 log units) from the limit.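

In this assay, compound 4 stops at a limit, > 100000 nM, and gives no number. Phenyl, the first ring shown at this aromatic carbon, replaces trifluoromethoxy in an at least 1.4-fold higher number from compound 3 to compound 4 (0.16 log units; that floor lies within the scatter), so a larger group of carbon only at this place brings no readable rise in toxicity in this test. The steps linking compound 4 to compound 1 and compound 2 cannot be read, and compound 3 remains the only compound with a number: the limit of > 100000 nM in this assay, at which 3 of the 4 values shown sit.

The compounds shown leave open whether an amine, a carboxylic acid or a longer chain at this aromatic carbon would give a number in this assay, and whether that number would stand beyond the scatter from compound 3. They also leave open how compound 1, compound 2 and compound 4 rank among themselves.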